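Swapping methyl for methoxy on compound 1

The compounds below may be only part of what the source reports. "The series", "measured", "known", "first", "only" and "open" are said of these compounds alone.

Measured so far in a functional assay on HeLa cells (Homo sapiens) for antiproliferative activity, read by MTT assay, with a stated time of 72 h; on this read-out lower numbers stand for stronger inhibition and higher numbers for weaker inhibition
Compound 1 `CCC(=O)NNC(=O)c1csc2ncc(-c3ccc(C)cc3)n12` gives 13000 nM
Compound 2 `CCCC(=O)NNC(=O)c1csc2ncc(-c3ccc(C)cc3)n12` gives 45600 nM

Compound 1 (13000 nM) has the lower number of the two. Compound 3 `CCC(=O)NNC(=O)c1csc2ncc(-c3ccc(OC)cc3)n12` differs from it in one place (methoxy in place of methyl on an aromatic carbon), with methoxy in place of methyl on an aromatic carbon. Within the data shown here, the only measured step (a 3.5-fold higher number from compound 1 to compound 2 (0.55 log units; beyond the scatter)) lies on a saturated chain, so it bears only loosely on this change. Among the measured compounds shown here, no measured step touches the aromatic ring, so no step beyond the scatter is expected in this assay here. For compound 3 the estimated value is 12000 nM (expected range 4000 nM to 36000 nM). This estimate means an expected step (a 1.1-fold lower number from compound 1 to compound 3 (0.03 log units; within the scatter)).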

Compound 3, half-maximal inhibitory concentration: 56200 nM
For compound 3 the middle estimate is 4.7-fold (0.67 log units) below the measured one; measured number above the stated range.
By their numbers in this assay, from the lowest: compound 1; then compounds 2 and 3 (each within the scatter of the next).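

Changing the aromatic ring matters in this assay: methoxy in place of methyl, para to a large group, gives a 4.3-fold higher number from compound 1 to compound 3 (0.64 log units; beyond the scatter). Among these compounds, the earlier compounds differed only in the saturated chain, so this is the first sign that the number also responds to a change on the ring, and here the methyl compound has the lower number. Nothing available explains this rise.

From the compounds shown here alone, it remains open whether hydrogen, chlorine or an amine at this place would give a lower number than methyl. Whether methoxy has a similar effect on the longer chain of compound 2 is also unresolved.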